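Ring-Nitrogen Acylation of Compound 1: An Expected Flat Step

This account rests on a few compounds, and the source may have more. Where it says the series, first, only, none or still open, it means among the compounds named here.

Compound 1 `CN1CCN(c2ccc(C3=NNC(c4ccc(N(C)C)cc4)C3)cc2)CC1`: 2.4%
Compound 2 `CN(C)c1ccc(C2CC(c3ccc(-n4ccnc4)cc3)=NN2)cc1`: 0.1%
Compound 3 `CN1CCN(c2ccc(C3=NN(C(=O)CCCl)C(c4ccc(N(C)C)cc4)C3)cc2)CC1`: -0.2%

In a functional assay on NCI-H1975 cells (Homo sapiens) for inhibition, read by sulforhodamine B assay, tested at 10 uM (a higher number here means more inhibition at the concentration tested (going by the name of the read-out), a lower number less inhibition), compound 1 gives the highest of the three numbers, but neither neighbour is separated from it beyond the scatter: the step of a number 2.3 percentage points lower from compound 1 to compound 2 (within the scatter) is the nearer one, and the step of a number 2.6 percentage points lower from compound 1 to compound 3 (within the scatter) the further one. All three compounds sit close to zero inhibition at this concentration.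

Compound 4 `Cc1ccc(C(=O)N2N=C(c3ccc(N4CCN(C)CC4)cc3)CC2c2ccc(N(C)C)cc2)cc1` differs from compound 1 by (4-methylphenyl)carbonyl in place of hydrogen on an amine nitrogen in a ring. The step that bears on this is a number 2.6 percentage points lower from compound 1 to compound 3 (within the scatter), which also replaced the hydrogen on the same ring amine nitrogen with a carbonyl-bearing group and stayed within the scatter. Nothing in these data points to a step beyond the scatter in either direction. Compound 4 is therefore expected to give 1%, in the range -8% to 10%. This estimate means a step of a number 1.4 percentage points lower from compound 1 to compound 4 (within the scatter), expected to remain within the scatter.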

Compound 4, a percentage reported as inhibition, at one concentration (the size of the read-out at that concentration, not a potency): -0.4%
Beside the measured number, compound 4's estimate is 1.4 percentage points above it; the range from low to high includes it.
By their numbers in this assay, from the lowest: compounds 4, 3, 2 and 1 (each within the scatter of the next).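

In this assay, the (4-methylphenyl)carbonyl group on this amine nitrogen in a ring, which brings a six-membered aromatic ring, stays level with hydrogen (a number 2.8 percentage points lower from compound 1 to compound 4 (within the scatter)). Setting 4-methylphenyl in place of 2-chloroethyl on the carbonyl carbon also gives no step beyond the scatter (a number 0.2 percentage points lower from compound 3 to compound 4 (within the scatter)), so two quite different carbonyl substituents read alike here. No evidence is available to explain this flat result. Going by these compounds, whether a carboxylic acid or a longer amine chain on this carbonyl would give a step beyond the scatter stays open.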